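Isopropylsulfonyl to dimethylsulfamoyl within the series

The source may hold more compounds than are shown below. What is called first, only, known or untested is meant among the compounds shown, and "the series" means these compounds.

Three compounds share one core and differ only in the ring amine on the aromatic carbon. Compound 1 `C=CC(=O)Nc1cc(Nc2ncc(Cl)c(Nc3ccccc3S(=O)(=O)C(C)C)n2)c(OC)cc1N1CCN(C)CC1` gives 43 nM in a functional assay on NCI-H1975 cells (Homo sapiens) for inhibition, read by CellTiter-Glo, with a stated time of 72 h; a higher number here means a weaker inhibitor of growth, a lower number a stronger inhibitor of growth. Compound 2 `C=CC(=O)Nc1cc(Nc2ncc(Cl)c(Nc3ccccc3S(=O)(=O)C(C)C)n2)c(OC)cc1N1CCN(C(C)C)CC1` gives 25 nM in this assay, and compound 3 `C=CC(=O)Nc1cc(Nc2ncc(Cl)c(Nc3ccccc3S(=O)(=O)C(C)C)n2)c(OC)cc1N1CCCCC1` gives 240 nM. Among these three numbers compound 1 sits second highest: its nearest neighbour is compound 2, with a 1.7-fold lower number from compound 1 to compound 2 (0.24 log units; within the scatter), a step within the scatter, and its furthest is compound 3, with a 5.6-fold higher number from compound 1 to compound 3 (0.75 log units; beyond the scatter). The remaining measured step is a 9.6-fold higher number from compound 2 to compound 3 (0.98 log units; beyond the scatter).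

Compound 4 `C=CC(=O)Nc1cc(Nc2ncc(Cl)c(Nc3ccccc3S(=O)(=O)N(C)C)n2)c(OC)cc1N1CCN(C)CC1` keeps the 4-methylpiperazin-1-yl of compound 1 and alters a different place: dimethylamino in place of isopropyl on a sulfonyl sulfur. None of the three measured steps touches the sulfonyl sulfur; all of them change the ring amine, so they bear on compound 4 only indirectly, showing that a small group swap at one site stayed within the scatter, as in a 1.7-fold lower number from compound 1 to compound 2 (0.24 log units; within the scatter), while replacing the ring type gave the modest 5.6-fold higher number from compound 1 to compound 3 (0.75 log units; beyond the scatter). For compound 4, with a group of matching heavy-atom count entering on the sulfonyl sulfur, the expected step is none beyond the scatter, direction uncertain, a 1.2-fold higher number from compound 1 to compound 4 (0.07 log units; within the scatter). Compound 4 is therefore estimated at 50 nM, within 20 nM to 150 nM.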

Compound 4, concentration for 50% growth inhibition: 31 nM
Compound 4: the middle estimate sits 1.6-fold (0.21 log units) above what was measured, and the stated range covers the measured number.
By their numbers in this assay, from the lowest: compounds 2, 4 and 1 (each within the scatter of the next); then compound 3.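

Dimethylamino in place of isopropyl on a sulfonyl sulfur is the first change at this position, and in this assay it gives a 1.4-fold lower number from compound 1 to compound 4 (0.14 log units; within the scatter). With the 4-methylpiperazin-1-yl held fixed, the sulfonyl sulfur therefore accepts a swap of two groups of 3 heavy atoms each, with a nitrogen entering among them, without a step beyond the scatter, whereas the ring amine site still holds the larger measured change, a 5.6-fold higher number from compound 1 to compound 3 (0.75 log units; beyond the scatter). No measurement here bears on why isopropyl and dimethylamino read alike at this position.

On these data alone, one swap on one ring amine is a narrow basis, so it stays open whether a larger or differently shaped group on the sulfonyl sulfur, such as a cyclopropyl, a morpholin-4-yl or a plain amino group, would stay within the scatter of compound 1. As far as these compounds go, it also stays open whether dimethylamino would behave the same way with the 4-isopropylpiperazin-1-yl of compound 2 or the piperidin-1-yl of compound 3.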